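The source may hold more compounds than are shown below. What is called first, only, known or untested is meant among the compounds shown, and "the series" means these compounds.

Working notes on the series.

Three compounds share the core shown for compound 1, `O=C(Nc1cc(F)c(-c2cn[nH]c2)c(F)c1)C1COc2ccccc2C1`, and have been measured in an assay on isolated protein for inhibition of Rho-associated protein kinase 2 (Homo sapiens); a lower number here means a stronger inhibitor, a higher number a weaker inhibitor. Compound 1 gives 4 nM. Compound 2, `COc1ccc2c(c1)CC(C(=O)Nc1ccc(-c3cn[nH]c3)c(OC)c1)CO2`, gives 3 nM. Compound 3, `COc1cc(-c2cn[nH]c2)ccc1NC(=O)C1COc2ccc(F)cc2C1`, gives 3 nM. Compound 3 stands level with compound 2 at the digits reported, the two together sitting at the low end of the three numbers, and its gap to compound 1 is within the scatter, so the three measured compounds cannot be told apart on these numbers.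

Compound 4, `COc1cc(-c2cn[nH]c2)ccc1NC(=O)C1COc2ccc(C)cc2C1`, has not yet been measured in this assay. It differs from compound 3 in one place: methyl in place of fluoro on an aromatic carbon, on the fused ring of the core. Within the data shown here, no step between measured compounds bears on this exchange, so there is nothing in the numbers to anchor a direction. The three measured compounds differ among themselves on the fused ring and on the aryl amide ring and still sit within the scatter of one another, which argues for a step no larger than the scatter in either direction. On that basis the step from compound 3 to compound 4 is expected to be a 1.3-fold higher number from compound 3 to compound 4 (0.12 log units; within the scatter), none beyond the scatter. For compound 4 the estimate in this assay is 4 nM, with a range from 1.5 nM to 10 nM.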

Compound 4, half-maximal inhibitory concentration: 4 nM
Compound 4: the middle estimate sits on the measured number at the digits printed, and the stated range covers the measured number.
By their numbers in this assay, from the lowest: compounds 2, 3, 1 and 4 (each within the scatter of the next).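

Among these compounds, this is the first step that changes a single place, and in this assay methyl in place of fluoro on an aromatic carbon of the fused ring gives a 1.3-fold higher number from compound 3 to compound 4 (0.12 log units; within the scatter). At this carbon, then, the two groups cannot be told apart on these numbers, although the exchange replaces one heavy atom with another and leaves the counts of hydrogen-bond donors and acceptors, the net charge and the ring count unchanged. No supporting measurement bears on this result, so the data show only the size of the step and give no account of it.

On these data alone, it remains open whether a group of another kind on this carbon, such as an amine, a carboxylic acid or a longer chain, would shift the number beyond the scatter, since fluoro and methyl alone define this position here. Also unresolved is whether the same exchange would give a similar step when the aryl amide ring carries the substituents of compound 1 or compound 2.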